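Aryl sulfonate series on colon cells: halogen and chain notes

The source may hold more compounds than are shown below. What is called first, only, known or untested is meant among the compounds shown, and "the series" means these compounds.

Compound 1 `CCN1CCN(c2ccc(S(=O)(=O)Oc3cccc(F)c3)cc2)C1=O`: in a functional assay on HT-29 cells (Homo sapiens) for antiproliferative activity, read by sulforhodamine B assay, with a stated time of 48 h (on this read-out higher numbers stand for weaker inhibition and lower numbers for stronger inhibition), compound 1 gives > 100000 nM, which is a limit of the assay and not a number.
Compound 2 `CCN1CCN(c2ccc(S(=O)(=O)Oc3cccc(Cl)c3)cc2)C1=O`: compound 2 gives 6800 nM.
Compound 3 `CCCN1CCN(c2ccc(S(=O)(=O)Oc3cccc(F)c3)cc2)C1=O`: compound 3 gives 18000 nM.

The change from compound 1 to compound 2 is chloro in place of fluoro on an aromatic carbon, and it gives an at least 14-fold lower number from compound 1 to compound 2 (1.16 log units; beyond the scatter). The cores of compound 1 and compound 3 differ by methyl in place of hydrogen on a saturated chain carbon, two bonds along the chain from an amide-type nitrogen in a ring, with an at least 5.5-fold lower number from compound 1 to compound 3 (0.74 log units; beyond the scatter). Compound 3 stands with a higher number than compound 2, the gap lying beyond the scatter.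

Compound 4 `CCCN1CCN(c2ccc(S(=O)(=O)Oc3cccc(Cl)c3)cc2)C1=O` is not yet measured. It differs from compound 3 by chloro in place of fluoro on an aromatic carbon; this is the same change as that from compound 1 to compound 2, now made on the core that carries the propyl chain. The step from compound 3 to compound 4 is expected to be a 12-fold lower number from compound 3 to compound 4 (1.08 log units; beyond the scatter), resting on an at least 14-fold lower number from compound 1 to compound 2 (1.16 log units; beyond the scatter). Compound 1 reached only (the limit of > 100000 nM in this assay, at which 1 of the 3 values shown sits), so the size of that earlier step is a lower bound and the expected step is kept near its floor. Compound 4 is estimated at 1500 nM, with a range from 300 nM to 7000 nM. Going by the values given here, only two measured steps underlie this, with no second example of either change.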

Compound 4, half-maximal inhibitory concentration: 13000 nM
Beside the measured number, compound 4's estimate is 8.7-fold (0.94 log units) below it, outside the stated range (above it).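

In this assay, chloro in place of fluoro on the core carrying the propyl chain gives a 1.4-fold lower number from compound 3 to compound 4 (0.14 log units; within the scatter), so the change does not carry over from the core of compound 1 at its earlier size: the same change on two cores in this assay, an at least 14-fold lower number (1.16 log units; beyond the scatter) from compound 1 to compound 2 and a 1.4-fold lower number (0.14 log units; within the scatter) from compound 3 to compound 4, at least 10-fold (1.02 log units) apart, beyond the scatter of two such steps

The added methyl on the chain, read on the chlorinated core, gives a 1.9-fold higher number from compound 2 to compound 4 (0.28 log units; within the scatter), and this change does not carry over at its earlier size either: the same change on two cores in this assay, an at least 5.5-fold lower number (0.74 log units; beyond the scatter) from compound 1 to compound 3 and a 1.9-fold higher number (0.28 log units; within the scatter) from compound 2 to compound 4, at least 10-fold (1.02 log units) apart, beyond the scatter of two such steps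

Both earlier steps start from compound 1, whose reading is a limit and not a number, so the series shows that neither step keeps its size from one core to the other, but not what sets the gap: the limit of > 100000 nM in this assay, at which 1 of the 4 values shown sits.

Still open, from the compounds shown here alone, is whether bromo or methoxy on the same aromatic carbon would follow chloro or fluoro. Going by these compounds, a longer chain such as butyl on the ring nitrogen also remains untested in these notes, on either the fluoro or the chloro core.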